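The compounds below may be only part of what the source reports. "The series", "measured", "known", "first", "only" and "open" are said of these compounds alone.

Going by the values given here, compound 2 `CCn1c(=O)c2nc(-c3ccc(S(=O)(=O)NCCCN(C)C)cc3)[nH]c2n(CC)c1=O` stands at the lowest of the two numbers so far in an assay for binding affinity to adenosine receptor A1 (Rattus norvegicus), read by radioligand binding (a lower number here means a stronger inhibitor, a higher number a weaker inhibitor), at 70 nM; compound 1 `CCn1c(=O)c2nc(-c3ccc(S(=O)(=O)N4CCOCC4)cc3)[nH]c2n(CC)c1=O` gives 310 nM, and the step of a 4.4-fold lower number from compound 1 to compound 2 (0.65 log units; beyond the scatter) separates them. Compound 3 `CCn1c(=O)c2nc(-c3ccc(S(=O)(=O)NCCN(C)C)cc3)[nH]c2n(CC)c1=O` differs from compound 2 by dimethylamino in place of (dimethylamino)methyl on a saturated chain carbon, two bonds along the chain from a sulfonamide nitrogen, so the chain carrying the dimethylamino group is shorter. Among the compounds with values here, no measured step alters this chain length; the only step known, from compound 1 to compound 2, exchanges a whole group and bears on the present change only loosely. For compound 3 a step of a 1.1-fold higher number from compound 2 to compound 3 (0.03 log units; within the scatter) is therefore expected, within the scatter, giving an estimated 75 nM with a range from 25 nM to 220 nM.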

Compound 3, half-maximal inhibitory concentration: 116 nM
Compound 3: middle estimate off by 1.5-fold (0.19 log units), on the low side; the range from low to high includes it.
By their numbers in this assay, from the lowest: compounds 2 and 3 (each within the scatter of the next); then compound 1.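

In this assay the change from 3-(dimethylamino)propyl to 2-(dimethylamino)ethyl gives a 1.7-fold higher number from compound 2 to compound 3 (0.22 log units; within the scatter) and so shows that this chain can be shortened without a step beyond the scatter. The shorter chain also still improves on morpholin-4-yl, with a 2.7-fold lower number from compound 1 to compound 3 (0.43 log units; beyond the scatter) on that exchange. Nothing measured here offers a reason for either step. The compounds shown leave open how a longer chain, such as 4-(dimethylamino)butyl, or a primary amine at the chain end would read in this assay on this same core.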